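The compounds below may be only part of what the source reports. "The series", "measured", "known", "first", "only" and "open" are said of these compounds alone.

Compound 1 `CS(=O)(=O)Oc1ccc(-c2cncn2C2CCN(C(=O)c3ccc(Cl)c(C(F)(F)F)c3)CC2)cc1` carries a methylsulfonyl on the oxygen of its aromatic ring; in an assay on HEK293 cells for antagonist activity at P2X purinoceptor 7 (Homo sapiens), read by fluorescence, with a stated time of 2 h (a higher number here means a weaker inhibitor, a lower number a stronger inhibitor), compound 1 gives 1570 nM. Compound 2 `O=C(Oc1ccc(-c2cncn2C2CCN(C(=O)c3ccc(Cl)c(C(F)(F)F)c3)CC2)cc1)c1ccccc1` has a benzoyl in that place. In this assay compound 2 reaches only a limit, > 10000 nM. The step is an at least 6.3-fold higher number from compound 1 to compound 2 (0.80 log units; beyond the scatter); because of the limit of > 10000 nM in this assay, at which 1 of the 2 values shown sits, its true size is not known. Compound 3 `O=C(Oc1ccc(-c2cncn2C2CCN(C(=O)c3ccc(Cl)c(C(F)(F)F)c3)CC2)cc1)c1cccs1` keeps the ester and differs by thiophen-2-yl in place of phenyl on a carbonyl carbon. Within the data shown here, only one measured step bears on this change, the one from the sulfonate to the benzoate, and it points to the aryl esters as the weaker side; no step compares one aryl ester with another. Compound 3 is therefore expected to stay near the limit, an expected step that the limit leaves unreadable from compound 2 to compound 3. The estimate for compound 3 in this assay is 15000 nM, with a range from 5000 nM to 50000 nM.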

Compound 3, half-maximal inhibitory concentration: > 10000 nM
Compound 3 gave a limit, no number (the forecaster's own chance of this, stated with the estimate: 70%); the middle value does not contradict the limit.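

In this assay, replacing the methylsulfonyl on the oxygen of the aromatic ring with (thiophen-2-yl)carbonyl gives an at least 6.3-fold higher number from compound 1 to compound 3 (0.80 log units; beyond the scatter). The weakening seen with benzoyl is therefore not confined to a phenyl on the carbonyl carbon: it also appears with a five-membered aromatic ring holding sulfur, at least in these two esters. Compound 3 gives only a limit, > 10000 nM, and the step between the two aryl esters cannot be read, so no order between phenyl and thiophen-2-yl can be stated: the limit of > 10000 nM in this assay, at which 2 of the 3 values shown sit.

The compounds shown leave open whether the carbonyl or the aromatic ring on it goes with the weakening, and whether any group on this oxygen improves on compound 1 at 1570 nM. An acetyl and a phenylsulfonyl in this place would separate those two parts.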